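Nitro for Cyano on Two Related Anilide Cores

This account rests on a few compounds, and the source may have more. Where it says the series, first, only, none or still open, it means among the compounds named here.

Measured compounds:
compound 1 `CC(O)(CSc1cccc(S(F)(F)(F)(F)F)c1)C(=O)Nc1ccc(C#N)cc1C(F)(F)F`, 37400 nM
compound 2 `CC(O)(CSc1cccc(S(F)(F)(F)(F)F)c1)C(=O)Nc1ccc([N+](=O)[O-])cc1C(F)(F)F`, 18900 nM
compound 3 `CC(O)(COc1ccc(S(F)(F)(F)(F)F)cc1)C(=O)Nc1ccc(C#N)c(C(F)(F)F)c1`, 25500 nM

The three compounds were tested in a functional assay on DU-145 cells (Homo sapiens) for antiproliferative activity, read by propidium iodide staining, with a stated time of 96 h; a higher number here means a weaker inhibitor, a lower number a stronger inhibitor. In this assay compound 1 gives 37400 nM, compound 2 gives 18900 nM and compound 3 gives 25500 nM. Compound 2 differs from compound 1 by nitro in place of cyano on an aromatic carbon, and this change made a step of a 2.0-fold lower number from compound 1 to compound 2 (0.30 log units; within the scatter). Compound 3 and compound 1 have different cores; the difference between the two cores is not broken down here. Compound 4 `CC(O)(COc1ccc(S(F)(F)(F)(F)F)cc1)C(=O)Nc1ccc([N+](=O)[O-])c(C(F)(F)F)c1` is not yet measured. It differs from compound 3 by nitro in place of cyano on an aromatic carbon. This is the same kind of change as that from compound 1 to compound 2, but not the same: in compound 2 the nitro group stands meta to a trifluoromethyl group, in compound 4 it stands ortho to a trifluoromethyl group. The expectation for compound 4 rests on the step from compound 1 to compound 2, which stayed within the scatter, so the estimated step is a 1.7-fold lower number from compound 3 to compound 4 (0.23 log units; within the scatter). Compound 4 is therefore expected to give about 15000 nM in this assay, estimated between 6000 nM and 35000 nM.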

Compound 4, half-maximal inhibitory concentration: 21200 nM
Beside the measured number, compound 4's estimate is 1.4-fold (0.15 log units) below it; the measured number falls inside the stated range.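

In this assay, nitro in place of cyano on an aromatic carbon gave a 1.2-fold lower number from compound 3 to compound 4 (0.08 log units; within the scatter). Set beside the earlier step, the result reads: the same change on two cores in this assay, a 2.0-fold lower number (0.30 log units; within the scatter) from compound 1 to compound 2 and a 1.2-fold lower number (0.08 log units; within the scatter) from compound 3 to compound 4, 1.6-fold (0.22 log units) apart, within the scatter of two such steps. The change thus carried from one core to the other with no difference beyond the scatter, but each step on its own also stays within the scatter, so the pair does not show that nitro and cyano differ in this read-out on either core, and two cores are too few to support a rule for the series.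

The compounds shown leave open whether a group of another kind on that aromatic carbon, such as an amine, a carboxylic acid or a chlorine atom, would move the number beyond the scatter. They also leave open whether nitro and cyano would stay as close on a core with a longer chain in place of the thioether or ether link.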